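This account rests on a few compounds, and the source may have more. Where it says the series, first, only, none or still open, it means among the compounds named here.

The measured compounds so far:

compound 1 `C=C1[C@@H](OC(C)=O)C[C@@H]2[C@](C)(CO[Si](C)(C)C(C)(C)C)[C@H](OC(C)=O)CC[C@@]2(C)[C@@H]1C[C@@H](Nc1ccc(OC)c(OC)c1)C1=CCOC1=O`: 5330 nM
compound 2 `C=C1[C@@H](OC(C)=O)C[C@@H]2[C@](C)(COC=O)[C@H](OC(C)=O)CC[C@@]2(C)[C@@H]1C[C@@H](Nc1ccc(O)cc1)C1=CCOC1=O`: 13400 nM
compound 3 `C=C1[C@@H](OC(C)=O)C[C@@H]2[C@](C)(COC=O)[C@H](OC(C)=O)CC[C@@]2(C)[C@@H]1C[C@@H](Nc1ccc(OC)c(OC)c1)C1=CCOC1=O`: 42800 nM

All three share one core and were tested in a functional assay on HT-29 cells (Homo sapiens) for cytotoxicity, read by sulforhodamine B assay; a higher number here means a weaker inhibitor, a lower number a stronger inhibitor. Compound 1 gives the lowest number of the three; compound 2 stands nearest to it and compound 3 furthest away. Two single changes link them. A change on an oxygen on a saturated carbon gave an 8.0-fold higher number from compound 1 to compound 3 (0.90 log units; beyond the scatter). A change of the group on the amine nitrogen gave a 3.2-fold higher number from compound 2 to compound 3 (0.50 log units; beyond the scatter).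

Compound 4 `C=C1[C@@H](OC(C)=O)C[C@@H]2[C@](C)(CO[Si](C)(C)C(C)(C)C)[C@H](OC(C)=O)CC[C@@]2(C)[C@@H]1C[C@@H](Nc1cccc2ccccc12)C1=CCOC1=O` has not yet been measured. Compared with compound 1 it differs in one place: naphthalen-1-yl in place of 3,4-dimethoxyphenyl on an amine nitrogen. Within the data shown here, only one measured step touches the same amine nitrogen, and that was the modest 3.2-fold higher number from compound 2 to compound 3 (0.50 log units; beyond the scatter), which involved different groups from the one entering here. Among the measured compounds shown here, there is no measured example of an aryl group without hydrogen-bond acceptors at this position, so the direction is open. A step of modest size, in either direction, is the reasonable expectation, with a small chance of a larger shift. On that basis the expected step is a 1.3-fold lower number from compound 1 to compound 4 (0.12 log units; within the scatter). Compound 4 is estimated at 4000 nM in this assay, within a range of 1200 nM to 13000 nM.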

Compound 4, half-maximal inhibitory concentration: 15000 nM
Beside the measured number, compound 4's estimate is 3.8-fold (0.57 log units) below it; the measured number lies above the stated range.
By their numbers in this assay, from the lowest: compound 1; then compounds 2 and 4 (each within the scatter of the next); then compound 3.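

In this assay, among these compounds, replacing the aryl group on the amine nitrogen while keeping the rest of compound 1 unchanged gives a 2.8-fold higher number from compound 1 to compound 4 (0.45 log units; beyond the scatter) and this is the first measured change at this position in which the silyl-bearing side of the molecule stays fixed. Both groups have 10 heavy atoms, so this position responds to a change in the kind of aryl group even when the heavy-atom count stays the same: naphthalen-1-yl has 2 six-membered aromatic rings of carbon only and 0 hydrogen-bond acceptors, whereas 3,4-dimethoxyphenyl has one such ring and 2 hydrogen-bond acceptors. No measurement available here explains why the number moves with this swap.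

The step changes the ring count and the oxygen-bearing methoxy groups together, so their separate contributions remain unresolved; a plain phenyl or a 4-methoxyphenyl on the same nitrogen, with the rest of compound 1 unchanged, would help pull them apart. Also open is whether a non-aromatic group on this nitrogen, such as cyclohexyl, or the other naphthalene attachment, naphthalen-2-yl, would give a lower or higher number than the groups shown.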